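Lengthening the chain on the ring nitrogen of compound 2

This account rests on a few compounds, and the source may have more. Where it says the series, first, only, none or still open, it means among the compounds named here.

Measured compounds:
Compound 1, `CCn1nc(C(=O)N[C@H]2COc3ccccc3N(C)C2=S)nc1Cc1ccccc1`: 17 nM
Compound 2, `CC(C)n1nc(C(=O)N[C@H]2COc3ccccc3N(C)C2=S)nc1Cc1ccccc1`: 360 nM
Compound 3, `CN1C(=S)[C@@H](NC(=O)c2nc(Cc3ccccc3)n(CCC(F)(F)F)n2)COc2ccccc21`: 1550 nM

In a functional assay on HT-29 cells (Homo sapiens) for inhibition, read by luminescence and CellTiter-Glo, with a stated time of 24 h (a lower number here means that less compound is needed, a higher number that more compound is needed for the effect), compound 2 gives 360 nM and stands second highest of the three, with compound 3 nearest and compound 1 furthest. Compound 4, `CN1C(=S)[C@@H](NC(=O)c2nc(Cc3ccccc3)n(CCCC#N)n2)COc2ccccc21`, differs from compound 2 by 3-cyanopropyl in place of isopropyl on an aromatic nitrogen. Among the measured compounds shown here, the nearest precedent is a 4.3-fold higher number from compound 2 to compound 3 (0.63 log units; beyond the scatter), where a different three-carbon chain grew to a longer chain on the same nitrogen; a 21-fold higher number from compound 1 to compound 2 (1.33 log units; beyond the scatter) also shows that enlarging this substituent raised the number. Compound 4 is therefore expected to move in the same direction, with a step of about a 2.5-fold higher number from compound 2 to compound 4 (0.40 log units; beyond the scatter). Compound 4 is estimated at 900 nM, within 300 nM to 2700 nM.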

Compound 4, half-maximal effective concentration: 2400 nM
For compound 4 the middle estimate is 2.7-fold (0.43 log units) below the measured one; the range from low to high includes it.
By their numbers in this assay, from the lowest: compound 1; then compound 2; then compounds 3 and 4 (each within the scatter of the next).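

In this assay a second longer chain also raises the number, with a 6.7-fold higher number from compound 2 to compound 4 (0.82 log units; beyond the scatter) on leaving isopropyl and a 140-fold higher number from compound 1 to compound 4 (2.15 log units; beyond the scatter) on leaving the ethyl group, the largest step shown on this aromatic nitrogen. Cyanomethyl in place of trifluoromethyl gives a 1.5-fold higher number from compound 3 to compound 4 (0.19 log units; within the scatter) so the nitrile and the trifluoromethyl chain are not told apart here. Nothing available accounts for these steps. Open, from the compounds shown here alone, is whether a methyl group on this nitrogen would give a lower number than the ethyl group of compound 1, and whether a chain ending in an amine or a carboxylic acid would stand apart from these two.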